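Nitro to amine on the anilino ring: lipophilicity expectation

The source may report more compounds than this note shows. Statements on the series, on what has been measured and on what is new or still open speak of the compounds shown alone.

Compound 2 `CCOC(=O)C1=C(C)NC(=O)NC1c1cn(C(=O)CNc2cccc([N+](=O)[O-])c2)c2ccccc12` gives 1.48 in a physicochemical assay for lipophilicity (on this read-out lower numbers stand for lower lipophilicity and higher numbers for higher lipophilicity), and it stands level with compound 1 `CCOC(=O)C1=C(C)NC(=O)NC1c1cn(C(=O)CNc2ccccc2[N+](=O)[O-])c2ccccc12`, which gives 1.48 in this assay. Going by the values given here, the single measured step, no change at the digits printed from compound 1 to compound 2 (within the scatter), moved the nitro group around the ring and left the read-out unchanged within the scatter. The step now considered, to compound 3 `CCOC(=O)C1=C(C)NC(=O)NC1c1cn(C(=O)CNc2ccccc2N)c2ccccc12`, is different in kind: 2-aminophenyl in place of 3-nitrophenyl on an amine nitrogen. Among the compounds with values here, no measured step exchanges a nitro group for an amino group, so the one known step bears on it only in showing that where the nitro group sat did not matter; it says nothing about removing it. With two acceptors leaving and one donor plus one acceptor entering, the estimated step for this assay is a number 0.38 log units lower from compound 2 to compound 3 (beyond the scatter), a modest decrease, but the uncertainty is wide. Compound 3 is therefore expected to give about 1.1, within a range from 0.6 to 1.6.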

Compound 3, partition coefficient: 0.74
Compound 3: middle estimate off by 0.36 log units, on the high side; measured number inside the range.
By their numbers in this assay, from the lowest: compound 3; then compounds 1 and 2 (each within the scatter of the next).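

Moving the nitro group had left this assay unchanged, but replacing it does not: amino in place of nitro on an aromatic carbon gives a number 0.74 log units lower from compound 1 to compound 3 (beyond the scatter), and 2-aminophenyl in place of 3-nitrophenyl on the amine nitrogen gives a number 0.74 log units lower from compound 2 to compound 3 (beyond the scatter), both beyond the scatter. This read-out therefore responds to which group the anilino ring carries, even though it did not distinguish compound 1 from compound 2, which differ only in where the nitro group sits. Nothing available gives a reason for the size of this step.

Going by these compounds, compound 3 alone carries the amino group, so it remains open whether the number would hold with that group elsewhere on the ring. On these data alone, how a hydroxyl, a methoxy group or a carboxylic acid would compare in its place also remains open.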